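The source may report more compounds than this note shows. Statements on the series, on what has been measured and on what is new or still open speak of the compounds shown alone.

Compound 1, `OCc1cc(OCc2cc(O)ccc2O)cc(Cl)c1O`, gives 38500 nM in a functional assay on Bel-7402 cells (Homo sapiens) for cytotoxicity, read by sulforhodamine B assay; on this read-out lower numbers stand for stronger inhibition and higher numbers for weaker inhibition.
Compound 2, `OCc1cc(OCc2cc(O)ccc2O)ccc1O`, gives 59000 nM in this assay.
Compound 3, `COCc1cc(O)cc(Cl)c1O`, gives 58100 nM in this assay.

All three measured compounds sit in the same broad region of this assay, and none of the gaps between them reaches beyond the usual scatter of repeated measurements. Compound 1 and compound 2 share a core and differ in one place only: hydrogen in place of chloro on an aromatic carbon. This change gave a 1.5-fold higher number from compound 1 to compound 2 (0.19 log units; within the scatter), so on its own it left the result essentially unchanged.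

Compound 3 carries a different core; the difference between the two cores is not broken down here. Its value lies within the scatter of both compound 1 and compound 2, so no order among the three can be read from these numbers.

Compound 4, `COCc1cc(O)ccc1O`, has not yet been measured. It differs from compound 3 by hydrogen in place of chloro on an aromatic carbon. Among the compounds with values here, this is the same kind of change as the one from compound 1 to compound 2, though the surroundings are not identical: in the first pair the place is meta to a hydroxymethyl group and meta to a large group, while in the second pair it is meta to a hydroxy group and meta to a methoxymethyl group.

Within the data shown here, the expectation for compound 4 rests on the one earlier example of this kind of change, which gave a 1.5-fold higher number from compound 1 to compound 2 (0.19 log units; within the scatter). Compound 4 is therefore expected to show a 1.5-fold higher number from compound 3 to compound 4 (0.17 log units; within the scatter) in this assay, a step that stays inside the scatter. The estimate for compound 4 is 85000 nM, with a likely range from 35000 nM to 200000 nM.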

Compound 4, half-maximal inhibitory concentration: > 100000 nM
Compound 4 was reported as a limit; the forecaster's own chance of this, stated with the estimate: 15%; middle value at least 1.1-fold (0.07 log units) from the limit.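

Compound 4 is reported only as a limit, not as a true number: the limit of > 100000 nM in this assay, at which 1 of the 4 values shown sits. On these data alone, replacing chloro with hydrogen on the aromatic carbon gives an at least 1.7-fold higher number from compound 3 to compound 4 (0.23 log units; that floor lies within the scatter), and how far the real step lies past that floor remains unknown. Both steps are printed as higher numbers, so the two results are compatible with the change carrying over from one core to the other, but this does not show that its size carries over, and neither step is shown to lie beyond the scatter: the same change on two cores in this assay, a 1.5-fold higher number (0.19 log units; within the scatter) from compound 1 to compound 2 and an at least 1.7-fold higher number (0.23 log units; that floor lies within the scatter) from compound 3 to compound 4; the limit leaves it open whether they differ.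

The compounds shown contain only chloro or hydrogen at this place, so they leave open how other groups there, such as fluoro, bromo, methyl or an amine, would behave in this assay. They also leave open what happens when the methoxymethyl group is exchanged for a longer chain or a carboxylic acid, and whether any change in this series can bring a value clearly beyond the scatter of the others.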